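Swapping a Trimethoxyphenyl Amine Substituent for Cyclohexyl

The source may report more compounds than this note shows. Statements on the series, on what has been measured and on what is new or still open speak of the compounds shown alone.

Of the compounds shown here, three have been tested so far: compound 1 `COc1ccc(Cn2nc(-c3ccccc3)c3cc(C(=N)Nc4ccc(N5CCN(C)CC5)cc4)nc(Nc4cc(OC)c(OC)c(OC)c4)c32)cc1`, compound 2 `COc1cc(Nc2nc(C(=N)Nc3cccc(C(F)(F)F)c3)cc3c(-c4ccccc4)n[nH]c23)cc(OC)c1OC` and compound 3 `COc1ccc(Cn2nc(-c3ccccc3)c3cc(C(=N)Nc4ccc(N5CCN(C)CC5)cc4)nc(NC4CCCCC4)c32)cc1`. In a functional assay on MDA-MB-231 cells (Homo sapiens) for cytotoxicity, read by MTT assay, with a stated time of 72 h (on this read-out higher numbers stand for weaker inhibition and lower numbers for stronger inhibition), compound 1 gives 890 nM. In this assay compound 2 gives 7600 nM, and compound 3 gives 129000 nM. Compound 1 and compound 3 differ in only one place, (cyclohexyl in place of 3,4,5-trimethoxyphenyl on a nitrogen on an aromatic ring), and this change produced a 140-fold higher number from compound 1 to compound 3 (2.16 log units; beyond the scatter). The difference between the cores of compound 1 and compound 2 is not broken down here; their two values simply show compound 2 with the higher number of the pair.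

Compound 4 `N=C(Nc1cccc(C(F)(F)F)c1)c1cc2c(-c3ccccc3)n[nH]c2c(NC2CCCCC2)n1` has not yet been measured in this assay. It is related to compound 2 by the same change that turns compound 1 into compound 3, namely (cyclohexyl in place of 3,4,5-trimethoxyphenyl on a nitrogen on an aromatic ring). Among the measured compounds shown here, because the one measured example of this change gave a 140-fold higher number from compound 1 to compound 3 (2.16 log units; beyond the scatter), the expected step is a 53-fold higher number from compound 2 to compound 4 (1.72 log units; beyond the scatter). This rests on a single pair and on compound 2 already standing at a high number, so the expectation is uncertain. The expected value for compound 4 is 400000 nM, with a likely range from 80000 nM to 2000000 nM.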

Compound 4, half-maximal inhibitory concentration: 24600 nM
The estimate for compound 4 lay 16-fold (1.21 log units) above the measured number, and the stated range ends above it.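

Putting cyclohexyl in place of 3,4,5-trimethoxyphenyl again weakened the result in this assay, but this time the change was modest, with a 3.2-fold higher number from compound 2 to compound 4 (0.51 log units; beyond the scatter). The direction of the change carried over from one core to the other, but its size did not, as the two steps show when set together: the same change on two cores in this assay, a 140-fold higher number (2.16 log units; beyond the scatter) from compound 1 to compound 3 and a 3.2-fold higher number (0.51 log units; beyond the scatter) from compound 2 to compound 4, 45-fold (1.65 log units) apart, beyond the scatter of two such steps. In this series, then, the size of the step on one core is a poor guide to its size on another, although two pairs cannot show which difference between the cores sets that size, nor whether the direction would hold on a third core.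

The compounds shown leave open how the step would look with other groups on that nitrogen, such as a plain phenyl ring or a short chain like ethyl. They also leave open which of the several differences between compound 1 and compound 2 accounts for the gap.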